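Thiophen-3-yl to 1H-pyrrol-3-yl: working notes on the series

The source may hold more compounds than are shown below. What is called first, only, known or untested is meant among the compounds shown, and "the series" means these compounds.

compound 1 `OC[C@H]1O[C@@H](n2cc(F)c3c(-c4ccco4)ncnc32)[C@H](O)[C@@H]1O`: 1200 nM
compound 2 `OC[C@H]1O[C@@H](n2cc(F)c3c(-c4c[nH]cn4)ncnc32)[C@H](O)[C@@H]1O`: "not determined" (no result reported)
compound 3 `OC[C@H]1O[C@@H](n2cc(F)c3c(-c4ccsc4)ncnc32)[C@H](O)[C@@H]1O`: 4900 nM

In a functional assay on HL-60 cells (Homo sapiens) for cytotoxicity, read by XTT assay, with a stated time of 3 days (on this read-out lower numbers stand for stronger inhibition and higher numbers for weaker inhibition), compound 3 carries the highest of the two numbers available, and compound 2 adds no number. The next entry is compound 4 `OC[C@H]1O[C@@H](n2cc(F)c3c(-c4cc[nH]c4)ncnc32)[C@H](O)[C@@H]1O`, with 1H-pyrrol-3-yl in place of thiophen-3-yl on an aromatic carbon. Going by the values given here, one measured step bears on this, a 4.1-fold higher number from compound 1 to compound 3 (0.61 log units; beyond the scatter), a modest exchange on the same carbon. A step of that size or smaller is therefore expected in this assay, leaning towards a lower number, although one step cannot settle the direction. The expected change is a 2.0-fold lower number from compound 3 to compound 4 (0.29 log units; within the scatter). The estimate for compound 4 is 2500 nM, with an expected range of 600 nM to 9000 nM.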

Compound 4, half-maximal inhibitory concentration: 1900 nM
Beside the measured number, compound 4's estimate is 1.3-fold (0.12 log units) above it, and the stated range covers the measured number.
By their numbers in this assay, from the lowest: compounds 1 and 4 (each within the scatter of the next); then compound 3.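

In this assay a second exchange on this carbon gives a 2.6-fold lower number from compound 3 to compound 4 (0.41 log units; beyond the scatter) and so sets thiophen-3-yl apart from 1H-pyrrol-3-yl. Going by these compounds alone, the comparison with furan-2-yl gives a 1.6-fold higher number from compound 1 to compound 4 (0.20 log units; within the scatter) and separates neither group, so among the numbers so far only thiophen-3-yl stands apart. No measured evidence accounts for either step.
Steps involving compound 2 cannot be read, as it has no number. As far as these compounds go, how an amine or a longer alkyl chain on this carbon would compare remains open.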